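A Second Hydroxy Returns to the Aryl Ring

A few compounds are considered here, and "the series" means these few. Any claim that something is new, unique, unknown or untested is made for them only; others in the source may bear on it.

Three hydrazones built on one shared core have been tested in a functional assay on SMMC-7721 cells (Homo sapiens) for antiproliferative activity, read by MTT assay, with a stated time of 72 h; a higher number here means a weaker inhibitor, a lower number a stronger inhibitor. Compound 1 `C/C(=N\NC(=O)c1cccc(S(=O)(=O)N2CCOCC2)c1)c1ccc(F)cc1` carries a 4-fluorophenyl on the carbon doubly bonded to nitrogen; in this assay compound 1 reaches only the limit of > 100000 nM. Compound 2 `C/C(=N\NC(=O)c1cccc(S(=O)(=O)N2CCOCC2)c1)c1ccccc1O` carries a 2-hydroxyphenyl in its place and gives 1370 nM, a change of an at least 72-fold lower number from compound 1 to compound 2 (1.86 log units; beyond the scatter). Compound 3 `C/C(=N\NC(=O)c1cccc(S(=O)(=O)N2CCOCC2)c1)c1cccc(O)c1` carries a 3-hydroxyphenyl, and compound 3 again sits only at a limit, > 100000 nM. Compound 3 therefore stands at the weak end of what has been measured: the step of an at least 72-fold higher number from compound 2 to compound 3 (1.86 log units; beyond the scatter) is large, while the step that the two limits leave unreadable from compound 1 to compound 3 cannot be read because the limit of > 100000 nM in this assay, at which 2 of the 3 values shown sit, sits at both of its ends.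

Compound 4 `C/C(=N\NC(=O)c1cccc(S(=O)(=O)N2CCOCC2)c1)c1cc(O)ccc1O` differs from compound 3 by hydroxy in place of hydrogen on an aromatic carbon. Among the measured compounds shown here, the new hydroxy stands where the hydroxy of compound 2 stood, so the step that bears most on it is the one from compound 1 to compound 2, which was large, and the loss when that hydroxy moved away in the step from compound 2 to compound 3. A large lowering of the number in this assay is therefore expected, estimated as an at least 40-fold lower number from compound 3 to compound 4 (1.60 log units; beyond the scatter). For compound 4 the expected value is 2500 nM, in a range from 600 nM to 40000 nM.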

Compound 4, half-maximal inhibitory concentration: > 100000 nM
Compound 4: no number, only a limit (the forecaster's own chance of this, stated with the estimate: 20%); middle value at least 40-fold (1.60 log units) away from the limit.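

Compound 2 and compound 4 both carry a hydroxy ortho to a large group, so this hydroxy does not by itself secure a measurable result. With the second hydroxy present on the ring, this assay shows an at least 72-fold higher number from compound 2 to compound 4 (1.86 log units; beyond the scatter). For compound 4, the reading of > 100000 nM is a limit of the assay and not a number.

The steps from compound 1 and from compound 3 to compound 4 cannot be read, because each has the same limit at both ends: the limit of > 100000 nM in this assay, at which 3 of the 4 values shown sit.

Going by these compounds, how the compounds at this limit rank against one another remains open, and so does whether the gain seen with compound 2 is lost only with a second hydroxy or with other groups on the ring as well. A methoxy group or an amine in place of the second hydroxy of compound 4 would test this, and a measured number for such a compound could be compared directly with that of compound 2.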